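Replacing cyanosulfanyl with its selenium counterpart: compound 3

The source may hold more compounds than are shown below. What is called first, only, known or untested is meant among the compounds shown, and "the series" means these compounds.

Measured compounds:
- compound 1 `CSc1ccc2ccccc2n1`: in a functional assay on MCF7 cells (Homo sapiens) for cytotoxicity, read by MTT assay, with a stated time of 72 h (on this read-out lower numbers stand for stronger inhibition of growth and higher numbers for weaker inhibition of growth), compound 1 gives only a limit, > 100000 nM.
- compound 2 `Cc1noc(C)c1CSC#N`: in this assay compound 2 gives 44600 nM.

Among the measured compounds shown here, compound 2 carries the only actual number so far; the other entry is the limit of > 100000 nM in this assay, at which 1 of the 2 values shown sits, so no measured step between compounds exists and nothing can be said about the distance between compound 1 and compound 2 beyond what the two entries show.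

Compound 3 `Cc1noc(C)c1C[Se]C#N` differs from compound 2 by a group of 3 heavy atoms (1 carbon, 1 nitrogen, 1 selenium; no ring) in place of a group of 3 heavy atoms (1 carbon, 1 nitrogen, 1 sulfur; no ring), on a saturated chain carbon bound to an aromatic carbon. The change is confined to the group on the saturated chain carbon bound to the aromatic carbon; the rest of the molecule is kept.

For the measured compounds named here, no measured step is available to calibrate this exchange. The expectation is a moderate move towards stronger growth inhibition in this assay, of a size that should sit beyond the usual scatter, while a result within the scatter of compound 2 cannot be ruled out. For compound 3 the estimated value in this assay is 15000 nM, with a range from 3000 nM to 60000 nM, which corresponds to an expected step of a 3.0-fold lower number from compound 2 to compound 3 (0.47 log units; beyond the scatter).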

Compound 3, concentration for total growth inhibition: 8300 nM
For compound 3 the middle estimate is 1.8-fold (0.26 log units) above the measured one; the measured number falls inside the stated range.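

In this assay, among the compounds shown here, replacing cyanosulfanyl with its selenium counterpart on a saturated chain carbon bound to an aromatic carbon gives the only readable step: a 5.4-fold lower number from compound 2 to compound 3 (0.73 log units; beyond the scatter). For the compounds shown here, this shows that the position responds to an exchange of sulfur for selenium alone, with the nitrile and the rest of the molecule kept, which the earlier entries could not show because they offered no step at all. No measured property at hand bears on this step, so its origin stays unassigned.

A single pair cannot show whether the same exchange would give a step of similar size on another core, or in cells other than those of this assay. Going by these compounds, it is also open whether an amine or a carboxylic acid in place of the selenium-bearing group, or a longer chain in place of the saturated chain carbon, would keep, enlarge or remove the growth inhibition seen with compound 3.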